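Methoxy in place of chloro: what to expect of compound 3

This account rests on a few compounds, and the source may have more. Where it says the series, first, only, none or still open, it means among the compounds named here.

Measured in a functional assay on RS4-11 cells (Homo sapiens) for inhibition, read by CCK-8 assay, with a stated time of 48 h; on this read-out higher numbers stand for weaker inhibition and lower numbers for stronger inhibition:
- compound 1 `O=C(NCCNS(=O)(=O)c1ccc(-c2ccccc2Oc2ccc([N+](=O)[O-])c([N+](=O)[O-])c2)s1)Nc1ccc([N+](=O)[O-])cc1`: 3000 nM
- compound 2 `O=C(NCCNS(=O)(=O)c1ccc(-c2ccccc2Oc2ccc([N+](=O)[O-])c([N+](=O)[O-])c2)s1)Nc1ccc(Cl)cc1`: 6700 nM

For the measured compounds named here, of the two numbers so far, compound 2 has the higher, at 6700 nM, which makes it the weaker inhibitor of the pair. The next compound, compound 3 `COc1ccc(NC(=O)NCCNS(=O)(=O)c2ccc(-c3ccccc3Oc3ccc([N+](=O)[O-])c([N+](=O)[O-])c3)s2)cc1`, keeps the shared core and differs from compound 2 at one place, with methoxy in place of chloro on an aromatic carbon, para to a large group, so that 4-chlorophenyl becomes 4-methoxyphenyl (methoxy in place of chloro on an aromatic carbon).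

Going by the values given here, only one measured step bears on this change. It is a 2.2-fold higher number from compound 1 to compound 2 (0.35 log units; beyond the scatter), in which chloro entered in place of nitro. Among the compounds with values here, no measured compound yet carries methoxy, so the data do not show the direction of the new step. A step no larger than that modest one is expected, perhaps with a slightly lower number, and quite possibly nothing beyond the scatter. The estimated step is a 1.2-fold lower number from compound 2 to compound 3 (0.09 log units; within the scatter). For compound 3 the expected value is 5500 nM, with an estimated range from 2500 nM to 11000 nM.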

Compound 3, half-maximal inhibitory concentration: 1400 nM
Compound 3: the middle estimate sits 3.9-fold (0.59 log units) above what was measured; the measured number lies below the stated range.
By their numbers in this assay, from the lowest: compound 3; then compound 1; then compound 2.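

In this assay, the change from chloro to methoxy gives a 4.8-fold lower number from compound 2 to compound 3 (0.68 log units; beyond the scatter) and so shows that this aromatic carbon, para to a large group, can also carry a substituent that lowers the number, whereas the earlier pair showed only a rise on going from nitro to chloro. The replacement of nitro by methoxy gives a 2.1-fold lower number from compound 1 to compound 3 (0.33 log units; beyond the scatter) and places methoxy below nitro as well, so the three groups now stand in the order methoxy, nitro, chloro, from the lowest number to the highest, with compound 3 the strongest inhibitor of the three. The data shown offer no measurement that would explain this order.

The compounds shown leave open whether a lower number is particular to methoxy or would also appear with a longer ether such as ethoxy, or with a hydroxyl or an amine on the same aromatic carbon. They also leave open whether the order of these three groups would survive a change elsewhere in the shared core, which all three compounds carry unchanged.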